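A few compounds are considered here, and "the series" means these few. Any claim that something is new, unique, unknown or untested is made for them only; others in the source may bear on it.

In a functional assay on A549 cells (Homo sapiens) for antiproliferative activity, read by MTT assay, with a stated time of 72 h (on this read-out lower numbers stand for stronger inhibition and higher numbers for weaker inhibition), compound 3 `C/C=C/C(=O)Nc1cccc(Oc2nc(Nc3ccc(OC)cc3)nc3c2CSCC3)c1` gives 22200 nM and compound 2 `CC(C)/C=C/C(=O)Nc1cccc(Oc2nc(Nc3ccn(C)n3)nc3c2CSCC3)c1` gives 33500 nM, two numbers within the scatter of each other. Compound 1 `C/C=C/C(=O)Nc1cccc(Oc2nc(Nc3ccn(C)n3)nc3c2CSCC3)c1` gives > 50000 nM, which is a limit of the assay and not a number. Compound 4 `COc1ccc(Nc2nc3c(c(Oc4cccc(NC(=O)/C=C/C(C)C)c4)n2)CSCC3)cc1` has no reading yet. It differs from compound 3 by isopropyl in place of methyl on a double-bonded chain carbon bound to a double-bonded chain carbon.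

The same exchange has one precedent, an at least 1.4-fold lower number from compound 1 to compound 2 (0.17 log units; that floor lies within the scatter). That step starts from a limit, so it is only a floor, and the floor lies within the scatter. The other measured step, an at least 2.2-fold lower number from compound 1 to compound 3 (0.35 log units; beyond the scatter), is 4-methoxyphenyl in place of 1-methyl-1H-pyrazol-3-yl on a nitrogen on an aromatic ring. It shows that the precedent was seen with the other group on that nitrogen, so it transfers only loosely.

The expected change in this assay is small, slightly towards a lower number, and is estimated as a 1.3-fold lower number from compound 3 to compound 4 (0.12 log units; within the scatter). For compound 4 the estimated value is 17000 nM, with an expected range of 7000 nM to 40000 nM.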

Compound 4, half-maximal inhibitory concentration: 25900 nM
Estimate against measurement, compound 4: 1.5-fold (0.18 log units) below, within the range that was stated.
By their numbers in this assay, from the lowest: compounds 3, 4 and 2 (each within the scatter of the next). At a limit, above all of these: compound 1.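

In this assay, isopropyl in place of methyl on a double-bonded chain carbon bound to a double-bonded chain carbon now has a step with a measured number at both ends (a 1.2-fold higher number from compound 3 to compound 4 (0.07 log units; within the scatter)), where the earlier precedent gave only a floor. On the core of compound 3 this change therefore stays within the scatter, and its comparison with the earlier step remains limited: the same change on two cores in this assay, an at least 1.4-fold lower number (0.17 log units; that floor lies within the scatter) from compound 1 to compound 2 and a 1.2-fold higher number (0.07 log units; within the scatter) from compound 3 to compound 4; the limit leaves it open whether they differ. With isopropyl in place, 4-methoxyphenyl in place of 1-methyl-1H-pyrazol-3-yl on the nitrogen also stays within the scatter (a 1.3-fold lower number from compound 2 to compound 4 (0.11 log units; within the scatter)), unlike the earlier step from compound 1 to compound 3: the same change on two cores in this assay, an at least 2.2-fold lower number (0.35 log units; beyond the scatter) from compound 1 to compound 3 and a 1.3-fold lower number (0.11 log units; within the scatter) from compound 2 to compound 4; the limit leaves it open whether they differ.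

From the compounds shown here alone, compound 1 gives > 50000 nM, which is a limit of the assay and not a number, so the true size of both steps from it stays open: the limit of > 50000 nM in this assay, at which 1 of the 4 values shown sits. Going by these compounds, whether an amine or a longer chain in place of isopropyl on that carbon would move the reading beyond the scatter also stays open.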